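A few compounds are considered here, and "the series" means these few. Any claim that something is new, unique, unknown or untested is made for them only; others in the source may bear on it.

Measured so far in an ADME assay on HMEC-1 cells (Homo sapiens) for antiproliferative activity; on this read-out lower numbers stand for stronger inhibition and higher numbers for weaker inhibition
- Compound 1 `COc1ccc(-c2snnc2-c2cc(OC)c(OC)c(OC)c2)cc1[N+](=O)[O-]` gives 26.4 nM
- Compound 2 `COc1ccc(-c2snnc2-c2cc(OC)c(OC)c(OC)c2)cc1OC` gives 75.8 nM
- Compound 3 `COc1ccc(-c2snnc2-c2cc(OC)c(OC)c(OC)c2)cc1` gives 24.6 nM

Compound 3 stands at the low end of these numbers, level with compound 1 and clearly apart from compound 2. Compound 4 `COc1ccc(-c2snnc2-c2cc(OC)c(OC)c(OC)c2)cc1N` differs from compound 3 by amino in place of hydrogen on an aromatic carbon, with the amino group on an aromatic carbon ortho to a methoxy group.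

Among the measured compounds shown here, no compound with an amino group has been measured, so the estimate must lean on the other groups exchanged with hydrogen at that carbon. Nitro and hydrogen are indistinguishable, as a 1.1-fold lower number from compound 1 to compound 3 (0.03 log units; within the scatter) stays within the scatter. Methoxy and hydrogen do differ, with a 3.1-fold lower number from compound 2 to compound 3 (0.49 log units; beyond the scatter) counted as modest. The measured exchanges therefore run from no visible change to a modest one, and in neither case does hydrogen carry the higher number. In this assay a small step towards a higher number is thus expected, most likely not beyond the scatter. The expected change is a 1.2-fold higher number from compound 3 to compound 4 (0.09 log units; within the scatter) in this estimate. For compound 4 the expected value is 30 nM, with an estimated range from 10 nM to 90 nM.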

Compound 4, half-maximal inhibitory concentration: 2.5 nM
Compound 4: middle estimate off by 12-fold (1.08 log units), on the high side; measured number below the stated range.
By their numbers in this assay, from the lowest: compound 4; then compounds 3 and 1 (each within the scatter of the next); then compound 2.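

In this assay, amino at this aromatic carbon, ortho to a methoxy group, brings a change that the earlier exchanges did not show (a 9.8-fold lower number from compound 3 to compound 4 (0.99 log units; beyond the scatter)), since hydrogen had stood level with nitro and only methoxy had moved the number away from hydrogen, towards weaker inhibition. The gap to the other two groups at this carbon is wider still (an 11-fold lower number from compound 1 to compound 4 (1.02 log units; beyond the scatter); a 30-fold lower number from compound 2 to compound 4 (1.48 log units; beyond the scatter)), which makes compound 4 the strongest inhibitor of the four and shows that this position can respond strongly to the group placed on it, not only modestly or barely. Nothing available here gives a reason for this gain.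

The compounds shown leave open whether the gain belongs to the free amino group itself or would also appear with a hydroxyl, a methylamino or an acetamido group on the same carbon. They also leave open whether it depends on the methoxy group to which the amino is ortho, a question that an analogue carrying an ethoxy group or a hydroxyl in place of that methoxy would bear on.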